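Methyl scans on two amide cores

This account rests on a few compounds, and the source may have more. Where it says the series, first, only, none or still open, it means among the compounds named here.

Values below come from a functional assay on MIA PaCa-2 cells (Homo sapiens) for inhibition, read by MTT assay, with a stated time of 72 h; on this read-out lower numbers stand for stronger inhibition and higher numbers for weaker inhibition.

compound 1 `O=C(Nc1cccc2cccnc12)c1ncccn1`: 330 nM
compound 2 `Cc1ccc2cccc(NC(=O)c3ncccn3)c2n1`: a limit of the assay, > 10000 nM
compound 3 `CC(C)(C)OC(=O)NCCOc1cc(NC(=O)c2cnccn2)c2ncccc2c1`: 870 nM

Compound 1 and compound 2 share a core; the difference is methyl in place of hydrogen on an aromatic carbon. This single change gives an at least 30-fold higher number from compound 1 to compound 2 (1.48 log units; beyond the scatter), the value of compound 2 sitting at the limit of > 10000 nM in this assay, at which 1 of the 3 values shown sits. Compound 3 carries a core whose difference from the core of compound 1 is not broken down here; in this assay compound 3 reads a larger number than compound 1 and is the highest of the two numbers at hand.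

Compound 4 `Cc1cnc(C(=O)Nc2cc(OCCNC(=O)OC(C)(C)C)cc3cccnc23)cn1` is not yet measured. It differs from compound 3 by methyl in place of hydrogen on an aromatic carbon. This is the same kind of change as between compound 1 and compound 2, not the same: there the methyl enters on a six-membered aromatic ring with 1 nitrogen, part of a fused or bridged system of two rings, meta to a fused ring and para to a fused ring; here it enters on a six-membered aromatic ring with 2 nitrogen, two atoms from the ring nitrogen and para to a large group. In both cases the entry is next to the ring nitrogen.

Among the measured compounds shown here, the expectation for compound 4 rests on the one measured example of this kind, an at least 30-fold higher number from compound 1 to compound 2 (1.48 log units; beyond the scatter). The place of entry differs, and a smaller loss is expected, a 2.9-fold higher number from compound 3 to compound 4 (0.46 log units; beyond the scatter). Compound 4 is thus estimated at 2500 nM, with a likely span from 700 nM to 10000 nM, and a real chance that only a limit is returned.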

Compound 4, half-maximal inhibitory concentration: 670 nM
The estimate for compound 4 lay 3.7-fold (0.57 log units) above the measured number, and the stated range ends above it.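

In this assay, the change from pyrazin-2-yl to 5-methylpyrazin-2-yl gives a 1.3-fold lower number from compound 3 to compound 4 (0.11 log units; within the scatter), so on this core the added methyl leaves the read-out within the scatter, and the same kind of change does not read alike on the two cores: the same change on two cores in this assay, an at least 30-fold higher number (1.48 log units; beyond the scatter) from compound 1 to compound 2 and a 1.3-fold lower number (0.11 log units; within the scatter) from compound 3 to compound 4, at least 39-fold (1.59 log units) apart, beyond the scatter of two such steps

Compound 2 reads > 10000 nM, which is a limit of the assay and not a number.

The two steps differ both in the ring that takes the methyl and in the rest of the core, and with one step on each core these differences cannot be separated, so the result shows that the size of this change does not transfer between these two cores but does not show which difference sets the gap.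

Still open, from the compounds shown here alone, is whether the result on the core of compound 3 holds for other groups at the same place on the pyrazine ring, such as ethyl, methoxy or an amine, or whether methyl is a special case. Also open, going by these compounds, is how far the reading of compound 3 and compound 4 depends on their side chain, for instance with a free amine in place of the carbamate at its end.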